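This account rests on a few compounds, and the source may have more. Where it says the series, first, only, none or still open, it means among the compounds named here.

Three compounds have been measured in a physicochemical assay for solubility, measured as kinetic solubility, at pH 2; a higher number here means a more soluble compound, a lower number a less soluble compound:

Compound 1, `CC(C)C(Nc1nccs1)c1ccc(-c2ccc3cccc(F)c3c2)[nH]c1=O`, gives 32900 nM.
Compound 2, `CC(C)[C@H](C[C@H]1CCNC1=O)c1ccc(-c2ccc3cccc(F)c3c2)[nH]c1=O`, gives 38300 nM.
Compound 3, `CCC(CC)(c1nnc[nH]1)c1ccc(-c2ccc3cccc(F)c3c2)[nH]c1=O`, gives 28500 nM.

All three share the same core and differ only in the group hanging from the carbon next to that core. Their numbers in this assay sit close together: compound 1 lies within the usual scatter of both compound 3, its nearest neighbour, and compound 2, its furthest, so no ordering among the three can be read from these values.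

The next compound, compound 4, `CC(C)C(Nc1nnc[nH]1)c1ccc(-c2ccc3cccc(F)c3c2)[nH]c1=O`, is compound 1 with one group exchanged: 4H-1,2,4-triazol-3-yl in place of 1,3-thiazol-2-yl on an amine nitrogen. Compound 3 already carries a triazole and sits in the same band as compound 1, so the exchange is not expected to move the number beyond the scatter. The step from compound 1 to compound 4 in this assay is expected to be small, a 1.1-fold higher number from compound 1 to compound 4 (0.04 log units; within the scatter), in either direction. Compound 4 is therefore expected to give about 36000 nM, somewhere between 16000 nM and 80000 nM.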

Compound 4, solubility: 39000 nM
Compound 4: the middle estimate sits 1.1-fold (0.03 log units) below what was measured, within the range that was stated.
By their numbers in this assay, from the lowest: compounds 3, 1, 2 and 4 (each within the scatter of the next).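

For the compounds shown here, compound 1 and compound 4 differ in one place only, so they give the first direct reading of a swap on this amine nitrogen: in this assay, 4H-1,2,4-triazol-3-yl in place of 1,3-thiazol-2-yl gives a 1.2-fold higher number from compound 1 to compound 4 (0.07 log units; within the scatter) and so shows no real difference. The swap takes out the ring sulfur and brings in a hydrogen-bond donor, yet the two numbers cannot be told apart in this assay, so these two five-membered aromatic rings are interchangeable here as far as this read-out goes. Nothing measured here offers an explanation for this result.

From the compounds shown here alone, both rings are five-membered aromatic rings, so it remains open whether a phenyl ring, a plain methyl or a group carrying a carboxylic acid on the same nitrogen would also leave the number within the scatter. Going by these compounds, it is also open whether this swap would give a similar step with a different group on the saturated chain carbon.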